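The source may report more compounds than this note shows. Statements on the series, on what has been measured and on what is new or still open speak of the compounds shown alone.

Compound 1 `C#CCNCc1cn(-c2cc(NC(=S)NCC)ncn2)cn1` carries a hydrogen on an amine nitrogen, and in an assay on isolated protein for inhibition of Amine oxidase [flavin-containing] A (Homo sapiens), read by fluorescence and Amplex Red, with a stated time of 15 min (on this read-out lower numbers stand for stronger inhibition and higher numbers for weaker inhibition), compound 1 gives 4330 nM. Compound 2 `C#CCN(C)Cc1cn(-c2cc(NC(=S)NCC)ncn2)cn1` puts a methyl on that nitrogen instead. In this assay compound 2 gives > 50000 nM, which is a limit of the assay and not a number. That is an at least 11-fold higher number from compound 1 to compound 2 (1.06 log units; beyond the scatter). Compound 3 `C#CCN(CC)Cc1cn(-c2cc(NC(=S)NCC)ncn2)cn1` puts an ethyl on the nitrogen. In this assay compound 3 gives > 50000 nM, again a limit of the assay rather than a measured number. That is an at least 11-fold higher number from compound 1 to compound 3 (1.06 log units; beyond the scatter), while the comparison between the two limits is a step that the two limits leave unreadable from compound 2 to compound 3. Compound 3 therefore stands at the limit of > 50000 nM in this assay, at which 2 of the 3 values shown sit.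

Compound 4 `C#CCN(CCC)Cc1cn(-c2cc(NC(=S)NCC)ncn2)cn1` differs from compound 3 by methyl in place of hydrogen on a saturated chain carbon, two bonds along the chain from an amine nitrogen, so the ethyl on the nitrogen becomes a propyl. Among the measured compounds shown here, the steps that bear on this are the ones that lengthened the group on the nitrogen: the two large ones from compound 1, and the unreadable one from compound 2 to compound 3. Both substituted compounds already sit at the limit, so compound 4 is expected to remain there, with a step that the limit leaves unreadable from compound 3 to compound 4 that cannot be read. The estimate for compound 4 in this assay is 80000 nM, within 30000 nM to 300000 nM.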

Compound 4, half-maximal inhibitory concentration: > 50000 nM
Compound 4 ended at the assay's limit (the forecaster's own chance of this, stated with the estimate: 85%); the middle value lies beyond the limit too.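

In this assay, propyl in place of hydrogen on the amine nitrogen gives an at least 11-fold higher number from compound 1 to compound 4 (1.06 log units; beyond the scatter), so the loss seen with methyl and ethyl now extends to a third, longer group on that nitrogen. The steps from compound 2 and from compound 3 to compound 4 cannot be read, since both ends of each are limits of the assay, and lengthening the chain from methyl to ethyl to propyl therefore shows no measurable change in either direction. Compound 1, with hydrogen on that nitrogen, remains the only one of these compounds with a measured number, and the series now rests mostly on limits: the limit of > 50000 nM in this assay, at which 3 of the 4 values shown sit.

As far as these compounds go, the true values of compound 2, compound 3 and compound 4 stay unknown, and so does any order among them. From the compounds shown here alone, it also remains open whether a different group on that nitrogen, such as a butyl chain or a hydroxyethyl chain, would give a measured number in this assay or would stay at the limit as well.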